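Chloro for Dimethylsulfamoyl: Expected Cytotoxicity of Compound 4

The compounds below may be only part of what the source reports. "The series", "measured", "known", "first", "only" and "open" are said of these compounds alone.

Compound 1 `CN1CCN(CCNCc2cn(-c3ccc(F)cc3F)nc2-c2ccc(S(=O)(=O)N(C)C)cc2)CC1` was tested in an ADME assay on Huh-7 cells (Homo sapiens) for cytotoxicity; on this read-out lower numbers stand for higher toxicity in this test and higher numbers for lower toxicity in this test. In this assay compound 1 gives only a limit, > 20000 nM, and no number. Two companions from the same set were measured alongside it. Compound 3 `Cc1ccccc1-c1nn(Cc2ccccc2)cc1CNCCN1CCN(C)CC1` likewise reaches only a limit in this assay, > 20000 nM. Compound 2 `CCCN1CCC(CNCc2cn(-c3ccc([N+](=O)[O-])cc3)nc2-c2ccc(C(F)(F)F)cc2)CC1`, which carries a nitro group and a trifluoromethyl group, gives a number in this assay, 2300 nM. Among the measured compounds shown here, compound 1 thus stands at the limit of > 20000 nM in this assay, at which 2 of the 3 values shown sit; where it would fall beneath that limit is not known, and no pair of the measured compounds differs in one place only, so no measured step can be followed.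

Compound 4 `CN1CCN(CCNCc2cn(-c3ccc(F)cc3F)nc2-c2ccc(Cl)cc2)CC1` is still to be measured in this assay. It differs from compound 1 in one place: chloro in place of dimethylsulfamoyl on an aromatic carbon. Since compound 1 gives only a limit, the step can be read only against that limit. With compound 1 and compound 3 both sitting at the limit, the expectation is that compound 4 also shows little toxicity, and the step of an at least 1.3-fold lower number from compound 1 to compound 4 (0.12 log units; that floor lies within the scatter) is expected to be small or to lie within the scatter. Compound 4 is estimated at 15000 nM in this assay, with a likely range from 5000 nM to 40000 nM.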

Compound 4, half-maximal cytotoxic concentration: 19000 nM
The estimate for compound 4 lay 1.3-fold (0.10 log units) below the measured number, and the stated range covers the measured number.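

In this assay compound 4 gives 19000 nM, a number rather than a limit, so the change from 4-(dimethylsulfamoyl)phenyl to 4-chlorophenyl now has a measured figure on one side. Read against a limit, the step is an at least 1.0-fold lower number from compound 1 to compound 4 (0.02 log units; that floor lies within the scatter), and its true size stays unknown. Even so, the dimethylsulfamoyl group is not required at this place, para to a large group, for a high number in this test: chloro, a single heavy atom, still leaves the number high on the core of compound 1.

The compounds shown leave open whether another group at this place, such as an amine, a carboxylic acid or a longer chain, would keep the number this high. Where compound 1 would fall also remains unknown, for it stands only at a limit: the limit of > 20000 nM in this assay, at which 2 of the 4 values shown sit.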